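This account rests on a few compounds, and the source may have more. Where it says the series, first, only, none or still open, it means among the compounds named here.

Measured so far in an ADME assay on a cell-free system (plasma, Mus musculus) for protein binding:

Compound 1, `CNc1nccc(N2CC[C@H](NC(=O)Nc3ccc(Cl)c(C(F)(F)F)c3)C2)n1`: 99.8%
Compound 2, `CNc1nccc(N2CC[C@H](NC(=O)Nc3ccc(OC(F)(F)F)cc3)C2)n1`: 98.1%
Compound 3, `CNc1nccc(N2CC[C@H](NC(=O)Nc3ccc(C)c(Cl)c3)C2)n1`: 98.6%

All three compounds share the same core and differ only in the substituents on the aryl urea. Of the three values, compound 2 has the largest unbound fraction. Its gap to compound 3 lies within the usual scatter of this assay, so the two cannot be told apart. Its gap to compound 1 is beyond the scatter: compound 1 is clearly more strongly bound than compound 2.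

Compound 4, `CNc1nccc(N2CC[C@H](NC(=O)Nc3ccc(OC(F)F)cc3)C2)n1`, has not been measured. It differs from compound 2 by a single change: hydrogen in place of fluoro on a saturated chain carbon bound to two fluorine atoms and an oxygen on an aromatic ring. Among the measured compounds shown here, no measured pair shows this exact change, so the expected step rests only on the small size of the change. Within this series, swapping one substituent for a close neighbour did not always move the value beyond the scatter, and a change of one fluorine to hydrogen is expected to give a step from compound 2 to compound 4 of a 1.4-fold higher unbound fraction from compound 2 to compound 4 (0.15 log units; within the scatter), at most at the edge of the scatter, if anything toward a slightly larger unbound fraction. Compound 4 is therefore expected to give about 97.3% in this assay, with a likely range from 94.5% to 98.8%.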

Compound 4, plasma protein binding: 96.8%
Beside the measured number, compound 4's estimate is 1.2-fold (0.07 log units) (unbound fraction) below it; the range from low to high includes it.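

In this assay, among the compounds shown here, the swap of trifluoromethoxy for difluoromethoxy gives a 1.7-fold higher unbound fraction from compound 2 to compound 4 (0.23 log units; within the scatter), and this is the first step that isolates one change in one place. Taking one fluorine away from this carbon, with hydrogen entering in its place, therefore does not separate compound 4 from compound 2 beyond the usual spread of repeat measurements. Nothing at hand offers an explanation for the size or direction of this step.

The compounds shown leave open whether removing the remaining fluorines, which would give a plain methoxy group, would produce a step beyond the scatter. They also do not show how an amine or a carboxylic acid in place of the trifluoromethoxy group would behave.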